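The source may report more compounds than this note shows. Statements on the series, on what has been measured and on what is new or still open speak of the compounds shown alone.

Compound 1 `COc1ccccc1S(=O)(=O)/C=C/c1ccccn1` is the only one of the three measured compounds that returns a number: in an assay on U2OS cells for activation of nuclear factor erythroid 2-related factor 2 (Homo sapiens), read by chemiluminescence, with a stated time of 6 h (on this read-out higher numbers stand for an effect only at larger amounts of compound and lower numbers for an effect already at smaller amounts), compound 1 gives 9070 nM. Compound 3 `COc1ccccc1S(=O)(=O)/C=C/c1cccnc1` carries pyridin-3-yl in place of pyridin-2-yl on a double-bonded chain carbon bound to a double-bonded chain carbon; in this assay compound 3 reaches only the assay limit, and its value is > 10000 nM. The resulting step, an at least 1.1-fold higher number from compound 1 to compound 3 (0.04 log units; that floor lies within the scatter), is thus a floor rather than a measured size. Compound 2 `COc1ccc(S(=O)(=O)/C=C/c2ccccn2)cc1` differs from compound 1 in its core, a difference that is not broken down here; in this assay compound 2 likewise sits at the assay limit, > 10000 nM. Compound 4 `COc1ccc(S(=O)(=O)/C=C/c2cccnc2)cc1` bears the same change relative to compound 2, (pyridin-3-yl in place of pyridin-2-yl on a double-bonded chain carbon bound to a double-bonded chain carbon). Because compound 2 already sits at the limit of > 10000 nM in this assay, at which 2 of the 3 values shown sit, the step from compound 2 to compound 4 is expected to be a step that the limit leaves unreadable from compound 2 to compound 4, beside the earlier at least 1.1-fold higher number from compound 1 to compound 3 (0.04 log units; that floor lies within the scatter). Compound 4 is therefore estimated at about 15000 nM in this assay, most probably reported again only as a limit.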

Compound 4, half-maximal effective concentration: > 10000 nM
Compound 4: a limit, no number (the forecaster's own chance of this, stated with the estimate: 85%); the middle value is on the limit's open side.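

Among the compounds shown here, compound 4 sits at a limit, as compound 2 does, so no step between compound 2 and compound 4 can be read in this assay: the limit of > 10000 nM in this assay, at which 3 of the 4 values shown sit. The compounds shown leave open how large the difference between pyridin-3-yl and pyridin-2-yl is on the core of compound 2.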